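The source may hold more compounds than are shown below. What is called first, only, known or untested is meant among the compounds shown, and "the series" means these compounds.

Measured in a functional assay on MCF7 cells (Homo sapiens) for inhibition, read by MTT assay, with a stated time of 72 h; a higher number here means a weaker inhibitor, a lower number a stronger inhibitor:
- compound 1 `CC(C)c1ccc(NC(=O)C2CCN(C/C=C/c3ccccc3)CC2)cc1`: 9100 nM
- compound 2 `CCCCCc1ccc(NC(=O)C2CCN(C/C=C/c3ccccc3)CC2)cc1`: 3740 nM
- compound 3 `COc1ccc(NC(=O)C2CCN(C/C=C/c3ccccc3)CC2)cc1`: > 100000 nM

Compound 3 stands at > 100000 nM, which is a limit of the assay and not a number. Compound 4 `O=C(Nc1cccc(F)c1)C1CCN(C/C=C/c2ccccc2)CC1` differs from it as follows: 3-fluorophenyl in place of 4-methoxyphenyl on an amide-type nitrogen. The 3-fluorophenyl takes the place of the 4-methoxyphenyl on an amide-type nitrogen. Two large steps bear on this, an at least 10-fold higher number from compound 1 to compound 3 (1.04 log units; beyond the scatter) and an at least 26-fold higher number from compound 2 to compound 3 (1.42 log units; beyond the scatter), each placing methoxy where another group stood. The modest step of a 2.4-fold lower number from compound 1 to compound 2 (0.39 log units; beyond the scatter) only exchanges isopropyl for pentyl. Within the data shown here, no measured compound carries fluorine, so only a moderate move towards a lower number in this assay is expected. The expected change is an at least 3.3-fold lower number from compound 3 to compound 4 (0.52 log units; beyond the scatter). For compound 4 the estimate is 30000 nM, with an expected range of 8000 nM to 100000 nM.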

Compound 4, half-maximal inhibitory concentration: 33000 nM
Estimate against measurement, compound 4: 1.1-fold (0.04 log units) below; low and high end bracket the measured number.
By their numbers in this assay, from the lowest: compound 2; then compound 1; then compound 4. At a limit, above all of these: compound 3.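

Compound 3 sits at a limit of the assay and not at a number: the limit of > 100000 nM in this assay, at which 1 of the 4 values shown sits. The 3-fluorophenyl on the amide-type nitrogen gives a measurable value, with an at least 3.0-fold lower number from compound 3 to compound 4 (0.48 log units; beyond the scatter), so a measurable value here does not depend on an alkyl group on the aromatic ring. It still falls short of the 4-isopropylphenyl, with a 3.6-fold higher number from compound 1 to compound 4 (0.56 log units; beyond the scatter).

In compound 4 the fluorine and its place on the ring differ together from compound 3, and the two effects remain unseparated. A 4-fluorophenyl or a 3-chlorophenyl would bear on that question.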